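A Second Chloro Atom and Its Expected Lipophilicity Step

A few compounds are considered here, and "the series" means these few. Any claim that something is new, unique, unknown or untested is made for them only; others in the source may bear on it.

Of the compounds shown here, three from one series have been measured, and a fourth awaits measurement. Compound 1 `O=C1N=C(N2CCOCC2)CN1c1ccccc1` is the simplest of them; in a physicochemical assay for lipophilicity (a higher number here means a more lipophilic compound, a lower number a more polar compound), compound 1 gives 0.6. Compound 2 `O=C1N=C(N2CCOCC2)CN1c1ccc(Cl)cc1` carries one more substituent, and in this assay compound 2 gives 1.5. The change between them is chloro in place of hydrogen on an aromatic carbon and it produced a number 0.90 log units higher from compound 1 to compound 2 (beyond the scatter).

Compound 3 `O=C1N=C(N2CCOCC2)CN1Cc1ccccc1Cl` is built on a different core; the difference between the two cores is not broken down here. In this assay compound 3 gives 1, which sits between the other two measured numbers.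

Compound 4 `O=C1N=C(N2CCOCC2)CN1Cc1c(Cl)cccc1Cl` is the compound still to be measured. It differs from compound 3 by chloro in place of hydrogen on an aromatic carbon. Among the compounds with values here, this is the same kind of change as the one from compound 1 to compound 2, but not the same: there the chloro entered para to a large group, whereas here it enters ortho to a large group and meta to a chloro group.

Within the data shown here, the only measured example of this kind of change is the step from compound 1 to compound 2, so the expectation for compound 4 rests on that step together with the value of compound 3. The expected step is a number 0.70 log units higher from compound 3 to compound 4 (beyond the scatter), close to a number 0.90 log units higher from compound 1 to compound 2 (beyond the scatter). Compound 4 is therefore estimated at 1.7, with a likely range from 1.4 to 2.1.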

Compound 4, partition coefficient: 1.3
Compound 4: middle estimate off by 0.40 log units, on the high side; measured number below the stated range.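

In this assay the same kind of change gave a number 0.90 log units higher from compound 1 to compound 2 (beyond the scatter) on one core but only a number 0.30 log units higher from compound 3 to compound 4 (within the scatter) on the other, so the second step cannot be told apart from no difference at all. This shows that in these compounds the size of the step seen on the first core did not carry over to the second core, and so one step is a weak guide to the next; it does not show that the core alone sets the size of the step, since the two changes also differ in place, the new chloro in compound 4 being ortho to a large group and meta to a chloro group. Nothing shown here gives a measured reason for the two steps differing.

On these data alone, whether the step would stay this small with the chloro at another place on the aromatic ring of compound 3, or on a ring that carries no chloro yet, remains open. Also open, as far as these compounds go, is how a fluoro, a methoxy group or an amine would behave in place of the new chloro on each of the two cores.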